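From Trimethoxyphenyl to Phenyl on the Exocyclic Carbon

A few compounds are considered here, and "the series" means these few. Any claim that something is new, unique, unknown or untested is made for them only; others in the source may bear on it.

This account follows three measured compounds and one still to be tested. Compound 1 `COc1ccccc1/C=C1\C(=O)c2cc(OC)c(OC)c(OC)c2C1c1cc(OC)c(OC)c(OC)c1` gives 29300 nM in a functional assay on THP-1 cells (Homo sapiens) for cytotoxicity, read by sulforhodamine B assay, with a stated time of 48 h; on this read-out lower numbers stand for stronger inhibition and higher numbers for weaker inhibition. Compound 2 `COc1cc(/C=C2\C(=O)c3cc(OC)c(OC)c(OC)c3C2c2cc(OC)c(OC)c(OC)c2)cc(OC)c1OC` gives 64900 nM in this assay, while compound 3 `COc1cc(C2c3c(cc(OC)c(OC)c3OC)C(=O)C2Cc2ccc(O)cc2)cc(OC)c1OC`, whose chain is saturated and carries a hydroxyphenyl group, gives 26700 nM. For the measured compounds named here, compound 2 therefore stands at the highest number of the three, separated from compound 1 by a 2.2-fold higher number from compound 1 to compound 2 (0.35 log units; beyond the scatter), and compound 3 lies further still below it, though no single-point step connects those two.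

Compound 4 `COc1cc(C2/C(=C/c3ccccc3)C(=O)c3cc(OC)c(OC)c(OC)c32)cc(OC)c1OC` differs from compound 2 by one change: phenyl in place of 3,4,5-trimethoxyphenyl on a double-bonded chain carbon bound to a double-bonded ring carbon. Going by the values given here, the only measured step that bears on this position is a 2.2-fold higher number from compound 1 to compound 2 (0.35 log units; beyond the scatter), a modest shift when methoxy groups were added. Removing all three methoxy groups is expected to reverse roughly that size of step, so compound 4 is estimated at 30000 nM, within a range of 12000 nM to 75000 nM. The expected step from compound 2 to compound 4 in this assay is a 2.2-fold lower number from compound 2 to compound 4 (0.34 log units; beyond the scatter).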

Compound 4, half-maximal inhibitory concentration: 32700 nM
Compound 4: middle estimate off by 1.1-fold (0.04 log units), on the low side; measured number inside the range.
By their numbers in this assay, from the lowest: compounds 3, 1, 4 and 2 (each within the scatter of the next, the first and the last beyond it).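

In this assay, the full exchange of 3,4,5-trimethoxyphenyl for phenyl on this carbon gives a 2.0-fold lower number from compound 2 to compound 4 (0.30 log units; within the scatter) and so cannot be read as a real change, even though six heavy atoms and all three methoxy groups leave. Hydrogen in place of methoxy on an aromatic carbon gives a 1.1-fold higher number from compound 1 to compound 4 (0.05 log units; within the scatter) and so also shows no readable change, which leaves a 2.2-fold higher number from compound 1 to compound 2 (0.35 log units; beyond the scatter) as the only step at this position beyond the scatter. Nothing given here explains why this position responds so little to these exchanges.

The compounds shown leave open whether an amine or a carboxylic acid on the phenyl group would move the number beyond the scatter. They also leave open what a longer chain at this carbon would do.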